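A few compounds are considered here, and "the series" means these few. Any claim that something is new, unique, unknown or untested is made for them only; others in the source may bear on it.

Of the compounds shown here, three share one core and have been tested. Compound 1 `CCOC(=O)C1=C(Nc2ccccc2)S/C(=C\c2ccc(OC)cc2)C1=O` gives 14.7% in a functional assay on MCF7 cells (Homo sapiens) for inhibition, read by MTT assay, with a stated time of 72 h, tested at 10 uM; on this read-out higher numbers stand for more inhibition at the one concentration tested (going by the name of the read-out) and lower numbers for less inhibition. Compound 2 `CCOC(=O)C1=C(Nc2ccccc2)S/C(=C\c2ccc(C(=O)O)cc2)C1=O` shows only a limit of this assay, < 10%, not a number (the limit of < 10% in this assay, at which 1 of the 3 values shown sits). Compound 3 `CCOC(=O)C1=C(Nc2ccccc2)S/C(=C\c2ccc[nH]2)C1=O` gives 18.3% in this assay and stands at the top of the two plain numbers, although compound 1 lies within the scatter of it: a number 3.6 percentage points higher from compound 1 to compound 3 (within the scatter). The other steps, a number at least 4.7 percentage points lower from compound 1 to compound 2 (that floor lies within the scatter) and a number at least 8.3 percentage points higher from compound 2 to compound 3 (that floor lies within the scatter), also stay within the scatter. Compound 4 `CCOC(=O)C1=C(Nc2ccc(C(F)(F)F)cc2)S/C(=C\c2ccc[nH]2)C1=O` differs from compound 3 by trifluoromethyl in place of hydrogen on an aromatic carbon. Among the measured compounds shown here, none of the measured steps touches this part of the molecule, so no measured step bears on it directly. The expected step is therefore a number 1.7 percentage points higher from compound 3 to compound 4 (within the scatter), no larger than the scatter. Compound 4 is estimated to give about 20%, between 8% and 35%.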

Compound 4, a percentage reported as inhibition, at one concentration (the size of the read-out at that concentration, not a potency): 19.1%
Beside the measured number, compound 4's estimate is 0.9 percentage points above it; the range from low to high includes it.
By their numbers in this assay, from the lowest: compounds 1, 3 and 4 (each within the scatter of the next). At a limit, below all of these: compound 2.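

Among the compounds shown here, compound 4 gives the first look at this position, on a six-membered aromatic ring of carbon only and para to a large group, where the earlier compounds all carry hydrogen. In this assay, trifluoromethyl in place of hydrogen gives a number 0.8 percentage points higher from compound 3 to compound 4 (within the scatter), so this change cannot be told apart from no change at all. Nothing at hand gives a reason for a step of this size. As far as these compounds go, whether an amine or a nitrile at this position would give a step beyond the scatter stays open. So does whether trifluoromethyl would give a similar step with the 4-methoxyphenyl group of compound 1 in place of 1H-pyrrol-2-yl.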